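The source may report more compounds than this note shows. Statements on the series, on what has been measured and on what is new or still open speak of the compounds shown alone.

Measured in a functional assay on M21 cells (Homo sapiens) for antiproliferative activity, read by sulforhodamine B assay, with a stated time of 48 h; a lower number here means a stronger inhibitor, a higher number a weaker inhibitor:
- Compound 1 `Cc1ccccc1OS(=O)(=O)c1ccc(N2CCN(C)C2=O)cc1`: 2900 nM
- Compound 2 `Cc1ccc(OS(=O)(=O)c2ccc(N3CCN(C)C3=O)cc2)cc1`: > 100000 nM

Compound 2 gives > 100000 nM, which is a limit of this assay and not a number.

Compound 3 `CN1CCN(c2ccc(S(=O)(=O)Oc3ccc(Cl)cc3)cc2)C1=O` has chloro in place of methyl on an aromatic carbon of compound 2, para to a large group: chloro in place of methyl on an aromatic carbon.

Among the measured compounds shown here, one measured step bears on this, and only indirectly: an at least 34-fold higher number from compound 1 to compound 2 (1.53 log units; beyond the scatter), a large move with 4-methylphenyl in place of 2-methylphenyl. That step concerns where the methyl sits and gives no size for replacing methyl with chloro. With the substituent kept in the same place, compound 3 is expected to stay well short of compound 1, which gives 2900 nM, with only a modest shift towards a lower number, or none that can be read. The expected step is an at least 2.0-fold lower number from compound 2 to compound 3 (0.30 log units; that floor lies within the scatter). Compound 3 is estimated at 50000 nM, with an expected range from 8000 nM to 100000 nM.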

Compound 3, half-maximal inhibitory concentration: 43000 nM
The estimate for compound 3 lay 1.2-fold (0.07 log units) above the measured number; the measured number falls inside the stated range.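

Chloro in place of methyl at this place, para to a large group, gives a readable value in this assay, with an at least 2.3-fold lower number from compound 2 to compound 3 (0.36 log units; beyond the scatter), so a group at this place does not by itself remove all activity. Compound 2 gives > 100000 nM, which is a limit and not a number, so this step has only a lower bound and its true size stays unread: the limit of > 100000 nM in this assay, at which 1 of the 3 values shown sits. Chloro at this place still falls well short of the 2-methylphenyl group, with a 15-fold higher number from compound 1 to compound 3 (1.17 log units; beyond the scatter), so the change does not restore what the methyl gives at its other place.

From the compounds shown here alone, how a methoxy group or an amine would read para to a large group stays open. Also open, going by these compounds, is whether chloro in place of methyl would shift the value of compound 1 in the same direction.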